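Swapping the aryl ketone in a chalcone-like pyrazole series

The source may report more compounds than this note shows. Statements on the series, on what has been measured and on what is new or still open speak of the compounds shown alone.

Measured compounds:
compound 1, `COc1cc(-c2cc(/C=C/C(=O)c3ccc(Cl)c(Cl)c3)[nH]n2)cc(OC)c1OC`, 16600 nM
compound 2, `COc1ccc(-c2cc(/C=C/C(=O)c3ccc(N)cc3)[nH]n2)cc1OC`, 6570 nM
compound 3, `COc1ccc(-c2cc(/C=C/C(=O)c3cc(OC)c(OC)c(OC)c3)[nH]n2)cc1OC`, 2910 nM

In a functional assay on Hs-578T cells (Homo sapiens) for inhibition, read by sulforhodamine B assay, with a stated time of 48 h (a higher number here means a weaker inhibitor of growth, a lower number a stronger inhibitor of growth), compound 1 gives the highest of the three numbers; compound 2 sits lower and compound 3 lowest, both gaps beyond the scatter. Compound 4, `COc1ccc(C(=O)/C=C/c2cc(-c3cc(OC)c(OC)c(OC)c3)n[nH]2)cc1OC`, has not been measured. It differs from compound 1 in one place: 3,4-dimethoxyphenyl in place of 3,4-dichlorophenyl on a carbonyl carbon. Because compound 3 gives 2910 nM and compound 2 gives 6570 nM, both below compound 1, a step downward in this assay is expected for compound 4, of moderate size, a 3.0-fold lower number from compound 1 to compound 4 (0.48 log units; beyond the scatter). Compound 4 is estimated at 5500 nM, within a range from 2000 nM to 15000 nM.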

Compound 4, concentration for 50% growth inhibition: 2570 nM
For compound 4 the middle estimate is 2.1-fold (0.33 log units) above the measured one; low and high end bracket the measured number.
By their numbers in this assay, from the lowest: compounds 4 and 3 (each within the scatter of the next); then compound 2; then compound 1.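

On a carbonyl carbon, 3,4-dimethoxyphenyl in place of 3,4-dichlorophenyl gives a 6.5-fold lower number from compound 1 to compound 4 (0.81 log units; beyond the scatter) in this assay. Among the compounds shown here, with the rest of compound 1 unchanged, this single exchange moves the number beyond the scatter, something the earlier compounds, which differ from one another in more than one place, could not show. Nothing given here accounts for the size of this step.

The compounds shown leave open whether both methoxy groups are needed for the lower number. They also leave open how a hydroxyl group or a carboxylic acid in their place would read.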